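From Compound 1 to Compound 3: One Ring Group Exchanged

The compounds below may be only part of what the source reports. "The series", "measured", "known", "first", "only" and "open" are said of these compounds alone.

- Compound 1 (`C/C(=N\NC(=O)COc1cccc2ccccc12)c1ccc(C#N)cc1Br`) gives 12.7 ug/mL
- Compound 2 (`O=C(COc1cccc2ccccc12)N/N=C/c1ccccc1Cl`) gives 62.7 ug/mL

These numbers come from an ADME assay on HEL cells (Homo sapiens) for cytotoxicity (a lower number here means that less compound is tolerated, a higher number that more compound is tolerated), and compound 1 stands lowest of the two, with a gap to compound 2 that lies beyond the usual scatter. Compound 3 (`C/C(=N\NC(=O)COc1cccc2ccccc12)c1ccc(O)cc1`) has not yet been measured. It carries 4-hydroxyphenyl in place of 2-bromo-4-cyanophenyl on a carbon with a double bond to nitrogen. Going by the values given here, no two measured compounds differ in one place only, so no measurement shows what this exchange does. Among the compounds with values here, the sole guide is that compound 2 reaches 62.7 ug/mL in the same test. The expected step in this assay (a 3.1-fold higher number from compound 1 to compound 3 (0.50 log units; beyond the scatter)) points upward, towards more compound tolerated, and is expected to lie beyond the scatter. For compound 3 the estimated value is 40 ug/mL (expected range 15 ug/mL to 100 ug/mL).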

Compound 3, half-maximal cytotoxic concentration: 11.1 ug/mL
The estimate for compound 3 lay 3.6-fold (0.56 log units) above the measured number; measured number below the stated range.
By their numbers in this assay, from the lowest: compounds 3 and 1 (each within the scatter of the next); then compound 2.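

Going by these compounds alone, the exchange of 2-bromo-4-cyanophenyl for 4-hydroxyphenyl, on a carbon with a double bond to nitrogen, gives in this assay a 1.1-fold lower number from compound 1 to compound 3 (0.06 log units; within the scatter) and so provides the first direct reading at this position. The bromine and the nitrile both leave and a hydroxyl group enters, yet this assay cannot tell the two compounds apart. No measurement at hand accounts for this result.

Since the bromine, the nitrile and the hydroxyl group all differ at once, the compounds shown leave open what each contributes alone. As far as these compounds go, it also remains open whether a phenyl ring carrying an amine or a carboxylic acid at this place would stay within the scatter of compound 1.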